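Extending an aldehyde into a thiophene chalcone

A few compounds are considered here, and "the series" means these few. Any claim that something is new, unique, unknown or untested is made for them only; others in the source may bear on it.

Compound 1 `COc1ccc(-c2cc3ccccc3nc2C=O)cc1` carries a formyl group on its core. In a functional assay on MDA-MB-231 cells (Homo sapiens) for antiproliferative activity, read by XTT assay, with a stated time of 72 h (a higher number here means a weaker inhibitor, a lower number a stronger inhibitor), compound 1 reaches only the limit > 10000 nM, so no number is known for it. Among the measured compounds shown here, compound 2 `COc1ccc(-c2cc3ccccc3nc2/C=C/C(=O)c2ccccc2)cc1` gives 860 nM, and compound 3 `COc1ccc(-c2cc3ccccc3nc2/C=C/C(=O)c2c(OC)cccc2OC)cc1` gives 5630 nM; the single measured step of a 6.5-fold higher number from compound 2 to compound 3 (0.82 log units; beyond the scatter) shows that swapping the aryl group on the carbonyl carbon moves potency modestly. Compound 4 `COc1ccc(-c2cc3ccccc3nc2/C=C/C(=O)c2ccsc2)cc1` differs from compound 1 by 2-((thiophen-3-yl)carbonyl)ethenyl in place of formyl on an aromatic carbon. The same kind of extension that separates compound 1 from compound 2 is present here, so compound 4 is expected to lie near compound 2, with a step of an at least 7.6-fold lower number from compound 1 to compound 4 (0.88 log units; beyond the scatter). The estimate for compound 4 is 1300 nM, between 450 nM and 4000 nM.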

Compound 4, half-maximal inhibitory concentration: 1060 nM
Estimate against measurement, compound 4: 1.2-fold (0.09 log units) above; the range from low to high includes it.
By their numbers in this assay, from the lowest: compounds 2 and 4 (each within the scatter of the next); then compound 3. At a limit, above all of these: compound 1.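

Thiophen-3-yl in place of phenyl gives a 1.2-fold higher number from compound 2 to compound 4 (0.09 log units; within the scatter), so this assay does not separate the two rings on the carbonyl carbon. Against the 2,6-dimethoxyphenyl group of compound 3, the thiophene gives a 5.3-fold lower number from compound 3 to compound 4 (0.73 log units; beyond the scatter), so the loss seen with compound 3 does not extend to every new aryl group there. Compound 1 stands only at a limit of the assay, so an at least 9.4-fold lower number from compound 1 to compound 4 (0.97 log units; beyond the scatter) is a minimum for the extension from formyl: the limit of > 10000 nM in this assay, at which 1 of the 4 values shown sits.

Open, from the compounds shown here alone, is what a phenyl ring with a single methoxy group would give on the carbonyl carbon. Also open, going by these compounds, is whether a ring carrying an amine, or a plain alkyl chain, would serve there.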